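This account rests on a few compounds, and the source may have more. Where it says the series, first, only, none or still open, it means among the compounds named here.

Measured compounds in a functional assay on CCRF-CEM cells (Homo sapiens) for cytotoxicity, read by sulforhodamine B assay, with a stated time of 48 h, tested at 100 uM; a lower number here means a stronger effect, a higher number a weaker effect of the compound at the concentration tested:
Compound 1 `COc1cc(-c2cc(/C=C/C(=O)c3ccc(N)cc3)[nH]n2)cc(OC)c1OC`; compound 1 gives -21%.
Compound 2 `COc1ccc(-c2cc(/C=C/C(=O)c3ccc(OC)c(OC)c3)[nH]n2)cc1`; compound 2 gives -47%.
Compound 3 `COc1ccc(-c2cc(/C=C/C(=O)c3ccc(N)cc3)[nH]n2)cc1OC`; compound 3 gives -22%.

Compound 1 holds the highest of the three numbers in this assay. Compound 3 stands nearest to it, and the step of a number 1 percentage points lower from compound 1 to compound 3 (within the scatter) lies within the scatter, so the two cannot be ordered. Compound 2 stands furthest from compound 1, and the gap between their two values lies beyond the scatter.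

Compound 4 `COc1ccc(C(=O)/C=C/c2cc(-c3cc(OC)c(OC)c(OC)c3)n[nH]2)cc1` has not yet been measured in this assay. It differs from compound 1 by methoxy in place of amino on an aromatic carbon. Going by the values given here, the one measured step of a single change, a number 1 percentage points lower from compound 1 to compound 3 (within the scatter), concerns hydrogen in place of methoxy rather than methoxy in place of amino, so no measured step bears directly on this change. Compound 2 differs from compound 1 in more than one place, yet it also carries methoxy rather than amino on an aromatic carbon of the ketone-bearing ring; compound 2 gives -47%, a lower number than compound 1. On this indirect ground a step toward lower numbers is expected for compound 4 in this assay, probably beyond the scatter but of uncertain size. The expected step is a number 14 percentage points lower from compound 1 to compound 4 (beyond the scatter). For compound 4 the estimate is -35%, within -55% to -15%.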

Compound 4, a percentage reported as activity, at one concentration (the size of the read-out at that concentration, not a potency): -16%
The estimate for compound 4 lay 19 percentage points below the measured number; measured number inside the range.
By their numbers in this assay, from the lowest: compound 2; then compounds 3, 1 and 4 (each within the scatter of the next).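

In this assay, going by these compounds alone, the exchange of 4-aminophenyl for 4-methoxyphenyl on the shared core gives a number 5 percentage points higher from compound 1 to compound 4 (within the scatter) and is the first reading of a single change at this position, on an aromatic carbon para to a large group. At the one concentration tested, amino and methoxy cannot be told apart here, so this exchange alone does not reproduce the separate standing of compound 2 at -47% in this series, a compound that differs from compound 1 in more than one place. No measurement on hand bears on the reason the two groups read alike at this position.

Still open, going by these compounds, is whether the position tolerates groups of other kinds, such as a hydroxyl, a dimethylamino group, a carboxylic acid or a longer alkoxy chain, in place of amino or methoxy. Also open, on these data alone, is whether the same exchange reads alike on the core of compound 3, and whether a reading at a single concentration would hold across a range of concentrations in this assay for compound 1 and compound 4.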